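The compounds below may be only part of what the source reports. "The series", "measured", "known", "first", "only" and "open" are said of these compounds alone.

In a functional assay on SGC-7901 cells (Homo sapiens) for antiproliferative activity, read by MTT assay, with a stated time of 72 h (on this read-out lower numbers stand for stronger inhibition and higher numbers for weaker inhibition), compound 1 (`COc1ccc(-c2sc(C(=O)O)cc2-c2cc(OC)c(OC)c(OC)c2)cc1O`), which carries a hydroxy, gives 6100 nM as a measured number. Compound 2 (`COc1ccc(-c2sccc2-c2cc(OC)c(OC)c(OC)c2)cc1OCc1ccccc1`) has only a limit, > 100000 nM as its entry, and no number. Compound 3 (`COc1ccc(-c2sccc2-c2cc(OC)c(OC)c(OC)c2)cc1O`) has hydrogen in place of benzyl on an oxygen on an aromatic ring, benzyloxy to hydroxy (hydrogen in place of benzyl on an oxygen on an aromatic ring). No measured step sizes this change. A large move toward stronger inhibition is expected (an at least 200-fold lower number from compound 2 to compound 3 (2.30 log units; beyond the scatter)). That expectation rests on compound 1, whose hydroxy goes with 6100 nM in this assay as a measured number. Compound 3 is estimated at 500 nM (expected range 20 nM to 10000 nM).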

Compound 3, half-maximal inhibitory concentration: 580 nM
The estimate for compound 3 lay 1.2-fold (0.06 log units) below the measured number; measured number inside the range.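

In this assay, hydrogen in place of benzyl on the oxygen on the aromatic ring gives an at least 170-fold lower number from compound 2 to compound 3 (2.23 log units; beyond the scatter). Compound 2 has a limit and not a number: the limit of > 100000 nM in this assay, at which 1 of the 3 values shown sits. Hydrogen in place of carboxy on an aromatic carbon gives an 11-fold lower number from compound 1 to compound 3 (1.02 log units; beyond the scatter), so a measured number in the hydroxy compounds does not depend on the carboxy.

Open, on these data alone, is how an acetyl group or a longer alkyl chain on that oxygen would read in this assay. Also open, as far as these compounds go, is how a primary amide would read in place of the carboxy.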